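Replacing the amino link of compound 3 with phenyl

The source may hold more compounds than are shown below. What is called first, only, known or untested is meant among the compounds shown, and "the series" means these compounds.

In a functional assay on SEM cells (Homo sapiens) for cytotoxicity, with a stated time of 72 h (on this read-out lower numbers stand for an effect already at smaller amounts and higher numbers for an effect only at larger amounts of compound), compound 1 `C=C[C@@](C)(/C=C/c1ccc(Nc2ccccc2)cc1)CCC=C(C)C` gives > 36600 nM, which is a limit and not a number. Compound 2 `C=C[C@@](C)(/C=C/c1ccc(Nc2ccc(OC)cc2)cc1)CCC=C(C)C` gives > 36600 nM, again a limit. Compound 3 `C=C[C@@](C)(/C=C/c1ccc(Nc2ccc(Cl)c(F)c2)cc1)CCC=C(C)C` gives > 36600 nM, also a limit, and that is all that is known of its standing.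

Compound 4 `C=C[C@@](C)(/C=C/c1ccc(-c2ccccc2)cc1)CCC=C(C)C` differs from compound 3 by phenyl in place of (4-chloro-3-fluorophenyl)amino on an aromatic carbon. The nearest measured changes altered the ring on that nitrogen, giving a step that the two limits leave unreadable from compound 1 to compound 3 and a step that the two limits leave unreadable from compound 2 to compound 3, while adding methoxy gave a step that the two limits leave unreadable from compound 1 to compound 2. For the measured compounds named here, none of them removes the nitrogen, so no measured step matches this change directly. The series as a whole shows (the limit of > 36600 nM in this assay, at which 3 of the 3 values shown sit), and compound 4 is expected to resemble these three and probably to return a limit as well. The expected step is a step that the limit leaves unreadable from compound 3 to compound 4, with no direction that the data can support. The estimate for compound 4 is 40000 nM, within an expected range from 15000 nM to 100000 nM.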

Compound 4, half-maximal effective concentration: > 36600 nM
Compound 4: a limit, no number; the forecaster's own chance of this, stated with the estimate: 75%; the middle value is on the limit's open side.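

In this assay compound 4 gives > 36600 nM, which is a limit and not a number. Its steps from compound 1, compound 2 and compound 3 cannot be read. How these four compounds differ from one another on this read-out stays open, since all share one reading: the limit of > 36600 nM in this assay, at which 4 of the 4 values shown sit.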